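Piperazine substitution in a chalcone-amide series

This account rests on a few compounds, and the source may have more. Where it says the series, first, only, none or still open, it means among the compounds named here.

Measured compounds in a functional assay on A549 cells (Homo sapiens) for inhibition, read by MTT assay; on this read-out lower numbers stand for stronger inhibition and higher numbers for weaker inhibition:
compound 1, `O=C(CN1CCC(Cc2ccccc2)CC1)Nc1ccc(C(=O)/C=C/c2cn(Cc3ccc(Br)cc3)nn2)cc1`, 40000 nM
compound 2, `CCCCCCCCCCn1cc(/C=C/C(=O)c2ccc(NC(=O)CN3CCN(c4ccccc4)CC3)cc2)nn1`, 52100 nM
compound 3, `O=C(CN1CCN(c2ccccc2F)CC1)Nc1ccc(C(=O)/C=C/c2cn(Cc3ccc(Br)cc3)nn2)cc1`, 14700 nM

Of these three, compound 3 gives the lowest number in this assay. Its gap to compound 1 lies beyond the scatter, and its gap to compound 2 is wider still, so among the measured compounds compound 3 stands out as the strongest inhibitor, though all three remain weak on this read-out.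

Compound 4, `CC(C)(C)OC(=O)N1CCN(CC(=O)Nc2ccc(C(=O)/C=C/c3cn(Cc4ccc(Br)cc4)nn3)cc2)CC1`, is not yet measured. It differs from compound 3 in one place: tert-butoxycarbonyl in place of 2-fluorophenyl on an amine nitrogen in a ring. For the measured compounds named here, no measured pair shows what such a change does, so the direction is open. The three measured compounds all sit close together at weak inhibition, which suggests that changes at this ring nitrogen move the number only modestly. The step from compound 3 to compound 4 is therefore expected to be small, a 1.7-fold higher number from compound 3 to compound 4 (0.23 log units; within the scatter), likely a mild weakening at most. Compound 4 is estimated at 25000 nM, within a range from 8000 nM to 70000 nM.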

Compound 4, half-maximal inhibitory concentration: 38400 nM
Beside the measured number, compound 4's estimate is 1.5-fold (0.19 log units) below it; the range from low to high includes it.
By their numbers in this assay, from the lowest: compound 3; then compounds 4, 1 and 2 (each within the scatter of the next).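

In this assay, for the compounds shown here, the change on this ring nitrogen gives the first step that can be read: tert-butoxycarbonyl in place of 2-fluorophenyl produces a 2.6-fold higher number from compound 3 to compound 4 (0.42 log units; beyond the scatter). The position therefore responds to the group it carries, and 2-fluorophenyl goes with the lower number, although this single pair cannot separate the loss of the aromatic ring from the arrival of the hydrogen-bond acceptors of tert-butoxycarbonyl. Nothing available here bears on why the number moves.

Going by these compounds, whether a small acetyl or methyl group on this nitrogen would give a number closer to that of compound 3 or compound 4 remains open. Also open, on these data alone, is what the fluorine contributes, since a plain phenyl group here appears only in compound 2, which also carries a decyl chain in place of the bromobenzyl group.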